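Removing the Aroyl Ester to Leave a Free Hydroxyl

The source may report more compounds than this note shows. Statements on the series, on what has been measured and on what is new or still open speak of the compounds shown alone.

In a functional assay on NFS-60 cells (Mus musculus) for inhibition, read by MTT assay, with a stated time of 72 h (a higher number here means a weaker inhibitor, a lower number a stronger inhibitor), compound 1 `Cc1ccc(C(=O)OC2(C(=O)Nc3ccc([N+](=O)[O-])cc3)CCCCC2)cc1` gives 45.4 nM. In this assay compound 2 `COc1ccc(C(=O)OC2(C(=O)Nc3ccc([N+](=O)[O-])cc3)CCCCC2)cc1` gives 38.8 nM. In this assay compound 3 `CCOC(=O)c1ccccc1C(=O)OC1(C(=O)Nc2ccc([N+](=O)[O-])cc2)CCCCC1` gives 488 nM.

Among these three numbers compound 1 stands second highest. Its nearest neighbour is compound 2, with a 1.2-fold lower number from compound 1 to compound 2 (0.07 log units; within the scatter). Compound 3 lies furthest away, well above compound 1, beyond the scatter.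

Compound 4 `O=C(Nc1ccc([N+](=O)[O-])cc1)C1(O)CCCCC1` arises from compound 1 through (hydrogen in place of (4-methylphenyl)carbonyl on an oxygen on a saturated carbon), so the whole aroyl ester disappears and a free hydroxyl remains. Within the data shown here, no measured step removes this group. The step from compound 1 to compound 2 only alters a substituent on the aromatic ring that leaves, and it stays within the scatter, so it says little about losing the ring altogether. The values of compound 1 and compound 3 show that altering the acyl part can move the number substantially. A large step upward in this assay, toward a weaker inhibitor, is therefore expected, with wide uncertainty.

For compound 4 the expected value is 2500 nM, between 300 nM and 20000 nM, an expected shift of a 55-fold higher number from compound 1 to compound 4 (1.74 log units; beyond the scatter).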

Compound 4, half-maximal inhibitory concentration: 716 nM
The estimate for compound 4 lay 3.5-fold (0.54 log units) above the measured number, and the stated range covers the measured number.
By their numbers in this assay, from the lowest: compounds 2 and 1 (each within the scatter of the next); then compounds 3 and 4 (each within the scatter of the next).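

In this assay, replacing the whole (4-methylphenyl)carbonyl group on the oxygen with hydrogen gives a 16-fold higher number from compound 1 to compound 4 (1.20 log units; beyond the scatter) and is a large move toward a weaker inhibitor. The earlier step only changed a substituent on the aromatic ring of this group and stayed within the scatter, whereas this one shows that removing the group altogether does matter, although compound 4 still gives a measurable number without it. Nothing available here explains the rise.

The compounds shown leave open how much of the aroyl ester is needed, for instance whether a small acetyl group on the same oxygen would behave more like compound 1 or more like compound 4. They also leave open whether a benzyl ether, or an amine in place of the oxygen, would give a similar number.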